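A few compounds are considered here, and "the series" means these few. Any claim that something is new, unique, unknown or untested is made for them only; others in the source may bear on it.

Measured in a functional assay on A549 cells (Homo sapiens) for antiproliferative activity, read by CCK-8 assay, with a stated time of 72 h; a higher number here means a weaker inhibitor, a lower number a stronger inhibitor:
- compound 1 `O=C(NO)c1ccc(COc2ccccc2)cc1`: 28000 nM
- compound 2 `Nc1cnccc1NC(=O)/C=C/c1ccc(COc2ccccc2)cc1`: > 32000 nM (a limit)

Compound 2 has no number on this read-out, since its > 32000 nM is only a limit. The next compound is compound 3 `O=C(/C=C/c1ccc(COc2ccccc2)cc1)NO`, and the change to it is hydroxy in place of 3-aminopyridin-4-yl on an amide-type nitrogen. Compound 1, which also carries hydroxy on an amide-type nitrogen, gives 28000 nM in this assay, so a stronger result beyond the scatter is expected. The expected change is an at least 4.0-fold lower number from compound 2 to compound 3 (0.60 log units; beyond the scatter). The estimate for compound 3 is 8000 nM, with an expected range of 1500 nM to 32000 nM.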

Compound 3, half-maximal inhibitory concentration: 5770 nM
Estimate against measurement, compound 3: 1.4-fold (0.14 log units) above, and the stated range covers the measured number.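

In this assay, hydroxy on the amide-type nitrogen gives a measured number where 3-aminopyridin-4-yl gives none, with an at least 5.5-fold lower number from compound 2 to compound 3 (0.74 log units; beyond the scatter). This step is a bound and not a size, since compound 2 has only a limit: the limit of > 32000 nM in this assay, at which 1 of the 3 values shown sits. With the hydroxy kept, 2-(hydroxycarbamoyl)ethenyl in place of hydroxycarbamoyl on the aromatic carbon also lowers the number, with a 4.9-fold lower number from compound 1 to compound 3 (0.69 log units; beyond the scatter).

From the compounds shown here alone, it remains open whether methoxy or an amine on the amide-type nitrogen would keep this result. A longer chain in place of the ethenyl link is also untested in the compounds shown.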